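A few compounds are considered here, and "the series" means these few. Any claim that something is new, unique, unknown or untested is made for them only; others in the source may bear on it.

Compound 1 `CC(C(=O)NCc1ccc(C(F)(F)F)cc1N1CCCCCC1)c1ccc(NS(C)(=O)=O)c(F)c1` and compound 2 `CC(C)CCSc1cc(C(F)(F)F)ccc1CNC(=O)C(C)c1ccc(NS(C)(=O)=O)c(F)c1` share one core and differ at a single aromatic carbon. Within the data shown here, in an assay on CHO cells for antagonist activity at transient receptor potential cation channel subfamily V member 1 (Homo sapiens), read by FLIPR (a higher number here means a weaker inhibitor, a lower number a stronger inhibitor), compound 1 gives 1.6 nM, and in this assay compound 2 gives 1.4 nM; the two values sit within the scatter of each other, and among the two numbers so far compound 2 holds the lower one without that gap meaning anything. Among the measured compounds shown here, the sole measured step, a 1.1-fold lower number from compound 1 to compound 2 (0.06 log units; within the scatter), exchanged the whole substituent at that carbon and left the number essentially where it was. Compound 3 `CC(C(=O)NCc1ccc(C(F)(F)F)cc1SCc1ccco1)c1ccc(NS(C)(=O)=O)c(F)c1` keeps the sulfur of compound 2 and carries furan-2-yl in place of isobutyl on a saturated chain carbon bound to a sulfur. For the measured compounds named here, no measured step shows what a change in the chain beyond the sulfur does; the one step that exists touched the same carbon and was flat. The expectation for compound 3 in this assay is therefore a step of a 1.3-fold higher number from compound 2 to compound 3 (0.11 log units; within the scatter), nothing beyond the scatter. Compound 3 is estimated at 1.8 nM, with a range from 0.6 nM to 5.5 nM.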

Compound 3, inhibition constant: 3.2 nM
Beside the measured number, compound 3's estimate is 1.8-fold (0.25 log units) below it; measured number inside the range.
By their numbers in this assay, from the lowest: compounds 2, 1 and 3 (each within the scatter of the next, the first and the last beyond it).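

In this assay, among these compounds, a 2.3-fold higher number from compound 2 to compound 3 (0.36 log units; beyond the scatter) is the first step at this position to pass beyond the scatter, if only modestly, so the part of the substituent past the sulfur can move the number where the exchange of the whole substituent did not. Set against the azepan-1-yl of compound 1, the ((furan-2-yl)methyl)sulfanyl group gives a 2.0-fold higher number from compound 1 to compound 3 (0.30 log units; within the scatter), which stays within the scatter, so the shift shows only against compound 2. Nothing at hand accounts for the step.

The compounds shown do not separate the ring from its oxygen, as furan-2-yl brings both in place of isobutyl. Going by these compounds, it remains open whether a phenyl or a cyclopentyl on that same saturated chain carbon bound to a sulfur would give a number like that of compound 2 or like that of compound 3.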